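Swapping the benzyl substituent on a cytotoxic quinoline-type amide

The source may report more compounds than this note shows. Statements on the series, on what has been measured and on what is new or still open speak of the compounds shown alone.

Among the measured compounds shown here, in a functional assay on MDA-MB-435 cells (Homo sapiens) for cytotoxicity, read by MTT assay, with a stated time of 72 h (on this read-out higher numbers stand for weaker inhibition and lower numbers for stronger inhibition), the numbers so far are modest. Compound 2 `COc1cccc(CNC(=O)c2nc(Br)c3cccnc3c2N[C@H]2CC[C@H](N)CC2)c1` gives 7000 nM, which is the higher of the two measured numbers, though compound 1 `N[C@H]1CC[C@H](Nc2c(C(=O)NCc3ccc(F)cc3)nc(N3CCCCC3)c3cccnc23)CC1` gives 5000 nM, and the gap between them lies within the usual scatter. Compound 3 `O=C(NCc1ccc(F)cc1)c1nc(Br)c2cccnc2c1NCc1ccccc1` reaches only the assay limit, > 20000 nM, so no number is known for it; it carries a benzylamino group where compounds 1 and 2 carry the diamine. The limit stands at the limit of > 20000 nM in this assay, at which 1 of the 3 values shown sits.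

Compound 4 `N[C@H]1CC[C@H](Nc2c(C(=O)NCc3ccc(Cl)cc3)nc(Br)c3cccnc23)CC1` keeps the core, the bromine and the diamine of compound 2 and differs from it in one place: 4-chlorophenyl in place of 3-methoxyphenyl on a saturated chain carbon bound to an amide-type nitrogen. For the measured compounds named here, no single-change step between measured compounds is recorded here, so the size of the effect cannot be read from the data. Compound 1, with a 4-fluorobenzyl amide and 5000 nM, suggests that a halogen at that position is tolerated. Compound 4 is therefore expected to sit near compound 2, with the step from a 1.3-fold lower number from compound 2 to compound 4 (0.10 log units; within the scatter) no larger than the scatter. The estimate for compound 4 is 5500 nM, within the range 2000 nM to 16000 nM.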

Compound 4, half-maximal inhibitory concentration: 1000 nM
Estimate against measurement, compound 4: 5.5-fold (0.74 log units) above; the whole stated range lies above it.
By their numbers in this assay, from the lowest: compound 4; then compounds 1 and 2 (each within the scatter of the next). At a limit, above all of these: compound 3.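

In this assay, 4-chlorophenyl in place of 3-methoxyphenyl on a saturated chain carbon bound to an amide-type nitrogen gives a 7.0-fold lower number from compound 2 to compound 4 (0.85 log units; beyond the scatter). Among the compounds shown here, this shows that the group at this place can move the read-out clearly, which the earlier compounds could not show, as none of them differed in only one place. No measurement shown explains the step, and the step alone cannot separate the loss of the methoxy group from the gain of chlorine or from the shift of the substituent's ring number from 3 to 4.

Still open, from the compounds shown here alone, is how 3-chlorophenyl or 4-methoxyphenyl would read at this place, which would pull the atom and its ring number apart. Also open, going by these compounds, is whether an amine on that ring, or a longer chain to the amide nitrogen, would keep the lower number.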